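Octyl replacing hydroxypropynyl on the sulfonamide aryl ring

The compounds below may be only part of what the source reports. "The series", "measured", "known", "first", "only" and "open" are said of these compounds alone.

Compound 1 `CC(=O)Nc1nc(-c2cccc(NS(=O)(=O)c3ccc(C#CCO)cc3)c2)cs1` is the weaker of the two compounds measured in a functional assay on A-375 cells (Homo sapiens) for antiproliferative activity, read by trypan blue exclusion, with a stated time of 48 h, tested at 5 uM; a higher number here means a weaker effect of the compound at the concentration tested, a lower number a stronger effect: compound 1 gives 99.3%, the highest of the two numbers, while compound 2 `CC(=O)Nc1nc(-c2cccc(NS(=O)(=O)c3cccc(C#CCO)c3)c2)cs1` gives 66.2%, lower by a margin beyond the scatter. Compound 3 `CCCCCCCCc1ccc(S(=O)(=O)Nc2cccc(-c3csc(NC(C)=O)n3)c2)cc1` differs from compound 1 in one place: octyl in place of 3-hydroxyprop-1-yn-1-yl on an aromatic carbon. The leaving group carries a triple bond, one hydrogen-bond donor and one acceptor; octyl brings none of these. Going by the values given here, no single-place step between measured compounds is at hand, so the direction rests on judgement; a modest downward step a number 14.3 percentage points lower from compound 1 to compound 3 (beyond the scatter) is expected. Compound 3 is estimated at 85%, within a range from 55% to 100%.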

Compound 3, a percentage reported as activity, at one concentration (the size of the read-out at that concentration, not a potency): < 1%
Compound 3: a limit, no number (the forecaster's own chance of this, stated with the estimate: 0%); middle value at least 84 percentage points away from the limit.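

In this assay, octyl in place of 3-hydroxyprop-1-yn-1-yl, on an aromatic carbon para to a large group, gives a number at least 98.3 percentage points lower from compound 1 to compound 3 (beyond the scatter). The group at this position, and not the shared core alone, therefore decides the read-out: the core of compound 1 can go from little effect to the bottom of the reported range. The value of compound 3 is a limit and not a number: the limit of < 1% in this assay, at which 1 of the 3 values shown sits.

Open, on these data alone, is whether chain length or the loss of the triple bond and hydroxyl carries the step. A butyl chain, a dodecyl chain, or an octyl chain ending in an amine or a carboxylic acid would separate these.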